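Cytotoxicity notes: nitrophenyl to cyanophenyl exchange

The source may hold more compounds than are shown below. What is called first, only, known or untested is meant among the compounds shown, and "the series" means these compounds.

Measured compounds:
Compound 1, `CC(=O)c1ccc(NCc2cncn2Cc2ccc(-c3ccccc3)cc2)cc1-c1ccccc1`. In a toxicity assay on NIH3T3 cells (Mus musculus) for cytotoxicity, read by resazurin assay (on this read-out higher numbers stand for an effect only at larger amounts of compound and lower numbers for an effect already at smaller amounts), compound 1 gives > 10000 nM, a limit of the assay and not a number.
Compound 2, `CN(C)c1ccc(NCc2cncn2Cc2ccc(-c3ccccc3)cc2)cc1-c1ccccc1`. In this assay compound 2 gives > 1000 nM, again only a limit of the assay.
Compound 3, `COC(=O)c1ccc(NCc2cncn2Cc2ccc([N+](=O)[O-])cc2)cc1-c1ccccc1`. In this assay compound 3 gives > 10000 nM, a limit of the assay.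

Compound 3 therefore stands at the upper limit of what this assay can report. It shares that position with one other compound: the limit of > 10000 nM in this assay, at which 2 of the 3 values shown sit. The remaining value sits lower, at the limit of > 1000 nM in this assay, at which 1 of the 3 values shown sits. Going by the values given here, the single measured step, a step that the two limits leave unreadable from compound 1 to compound 2, concerns dimethylamino in place of acetyl on an aromatic carbon and cannot be read in size, so it says nothing about the exchange considered here.

The next compound, compound 4, `COC(=O)c1ccc(NCc2cncn2Cc2cccc(C#N)c2)cc1-c1ccccc1`, differs from compound 3 by 3-cyanophenyl in place of 4-nitrophenyl on a saturated chain carbon bound to an aromatic nitrogen. Among the compounds with values here, no measured step touches this part of the structure. With compound 3 at a limit and nothing pointing to a readable change, the step that the limit leaves unreadable from compound 3 to compound 4 is expected to lie within the scatter, and compound 4 is estimated at 20000 nM, between 5000 nM and 100000 nM, most likely again reported only as a limit.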

Compound 4, half-maximal effective concentration: > 10000 nM
Compound 4: no number, only a limit; the forecaster's own chance of this, stated with the estimate: 80%; the middle value lies beyond the limit too.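

In this assay compound 4 gives > 10000 nM, a limit of the assay and not a number; compound 3 also stands at a limit, so the step between these two compounds cannot be read. The compounds shown leave open at what concentration any of the four has an effect in this assay, and whether 3-cyanobenzyl in place of 4-nitrobenzyl changes that concentration.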